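A few compounds are considered here, and "the series" means these few. Any claim that something is new, unique, unknown or untested is made for them only; others in the source may bear on it.

Measured so far, in a physicochemical assay for solubility, at pH 2; on this read-out higher numbers stand for higher solubility and lower numbers for lower solubility:

Compound 1 `CC(C)Nc1nc(NCc2ccco2)c2cccc(Cl)c2n1` gives a value that is a limit of the assay, >= 30000 nM.
Compound 2 `CC(C)Nc1nc(NCc2ccco2)c2ccc(Cl)cc2n1` gives a value that is also a limit of the assay, >= 30000 nM.
Compound 3 `Cc1cccc2c(NCc3ccco3)nc(NC(C)C)nc12` gives a value that is again a limit of the assay, >= 30000 nM.

All three compounds share the same set of atoms around a fused two-ring core carrying an isopropylamino group and a furanylmethylamino group, and they differ only in the small group on the carbon-only ring and where it sits. Compound 1 and compound 2 have the same atoms joined differently; the difference between the two cores is not broken down here.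

From compound 1 to compound 3 the change is methyl in place of chloro on an aromatic carbon. The step it made, a step that the two limits leave unreadable from compound 1 to compound 3, cannot be read, since both values sit at the same limit: the limit of >= 30000 nM in this assay, at which 3 of the 3 values shown sit.

Compound 4 `Cc1ccc2c(NCc3ccco3)nc(NC(C)C)nc2c1` has not yet been measured in this assay. It differs from compound 2 by methyl in place of chloro on an aromatic carbon. This is the same kind of change as from compound 1 to compound 3, though not the same, as the place differs: in compound 3 the methyl is ortho to a fused ring and meta to a fused ring, while in compound 4 it is meta to a fused ring and para to a fused ring.

Compound 4 is expected to show a step that the limit leaves unreadable from compound 2 to compound 4, that is, no readable change, resting on the fact that every value here sits at the limit, including that of compound 2, >= 30000 nM. The estimate for compound 4 is therefore 35000 nM, with a likely range from 15000 nM to 100000 nM, and most probably the assay will again report only a limit.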

Compound 4, solubility: >= 30000 nM
Compound 4 ended at the assay's limit (the forecaster's own chance of this, stated with the estimate: 80%); the middle value does not contradict the limit.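

Going from compound 2 to compound 4, with methyl in place of chloro, gives no step that can be read in this assay, because both results are limits and not numbers: the limit of >= 30000 nM in this assay, at which 4 of the 4 values shown sit.

The compounds shown leave open how far each one really lies beyond that limit, and whether chloro or methyl, or the place of either group, makes any difference in this assay.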